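Expected Cytotoxicity of Compound 3 after a Dimethoxyphenyl Exchange

A few compounds are considered here, and "the series" means these few. Any claim that something is new, unique, unknown or untested is made for them only; others in the source may bear on it.

Measured compounds:
compound 1, `N#Cc1cnn(-c2ccc(S(N)(=O)=O)cc2)c1N`: > 100000 nM
compound 2, `NS(=O)(=O)c1ccc(-n2ncc3c(=O)[nH]c(-c4ccc(Cl)cc4)nc32)cc1`: 23900 nM

Two compounds have been examined in a functional assay on HepG2 cells (Homo sapiens) for cytotoxicity, read by MTT assay, with a stated time of 72 h; on this read-out lower numbers stand for stronger inhibition and higher numbers for weaker inhibition. Compound 1 is reported in this assay only as a limit, > 100000 nM. Compound 2, in this assay, gives 23900 nM. Among the compounds with values here, compound 2 therefore holds the only numeric value shown, while the other entry sits at the limit of > 100000 nM in this assay, at which 1 of the 2 values shown sits. Within the data shown here, with only one number and one limit, no measured step between single-point changes exists from which the size of the next change could be read.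

The piece follows compound 2 to compound 3, `COc1ccc(-c2nc3c(cnn3-c3ccc(S(N)(=O)=O)cc3)c(=O)[nH]2)cc1OC`, which is not yet measured in this assay. The change is 3,4-dimethoxyphenyl in place of 4-chlorophenyl on an aromatic carbon.

Nothing measured here shows how this exchange acts in this assay. For compound 3 the expectation is a step from compound 2 that stays within the usual scatter, a 1.0-fold higher number from compound 2 to compound 3 (0.02 log units; within the scatter), with the direction left open. Compound 3 is estimated in this assay at 25000 nM, with a range from 8000 nM to 80000 nM.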

Compound 3, half-maximal inhibitory concentration: > 100000 nM
Compound 3: a limit, no number; the forecaster's own chance of this, stated with the estimate: 15%; at least 4.0-fold (0.60 log units) between middle value and limit.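

In this assay, the aromatic carbon between two ring nitrogen atoms proves sensitive to what it carries, which neither earlier compound could show: 3,4-dimethoxyphenyl in place of 4-chlorophenyl gives an at least 4.1-fold higher number from compound 2 to compound 3 (0.62 log units; beyond the scatter). Compound 3 is reported only as a limit, > 100000 nM, so this step gives a minimum size and not an exact one. Compound 2 therefore remains the only compound here with a numeric value, and the other entries are limits: the limit of > 100000 nM in this assay, at which 2 of the 3 values shown sit.

The exchange removes the chlorine and brings in the methoxy groups in a single step, and the compounds shown do not separate these two parts of the change. As far as these compounds go, how a phenyl carrying a single methoxy group, an amine or a carboxylic acid would read at this position in this assay remains open.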